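Moving the Methyl Group Around the Aryl Ring

This account rests on a few compounds, and the source may have more. Where it says the series, first, only, none or still open, it means among the compounds named here.

Compound 2 `Cc1ccc(N2CCN(CCCOc3ccc4c(=O)cc(-c5ccccc5)oc4c3)CC2)cc1` was tested in a functional assay for antagonist activity at Adrenergic receptor alpha-1 (Rattus norvegicus) (on this read-out lower numbers stand for tighter binding and higher numbers for weaker binding), where compound 2 gives 20.7 nM. Among the three measured compounds it stands second highest: compound 1 `O=c1cc(-c2ccccc2)oc2cc(OCCCN3CCN(c4ccccc4)CC3)ccc12`, which lacks the methyl group, gives 6.65 nM, while compound 3 `Cc1ccc(N2CCN(CCCCOc3ccc4c(=O)cc(-c5ccccc5)oc4c3)CC2)cc1`, with a chain one member longer, gives 195 nM. Within the data shown here, the one measured step that bears on the present question is the addition of the methyl group, a 3.1-fold higher number from compound 1 to compound 2 (0.49 log units; beyond the scatter).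

Compound 4 `Cc1ccccc1N1CCN(CCCOc2ccc3c(=O)cc(-c4ccccc4)oc3c2)CC1` keeps every atom of compound 2 but joins them differently: 2-methylphenyl in place of 4-methylphenyl on an amine nitrogen in a ring. Among the measured compounds shown here, no measured pair shows what shifting the methyl group within the same aromatic ring does, so the only guidance is that the methyl group itself, in the step from compound 1 to compound 2, moved the number upward by a modest amount. Since compound 4 still carries one methyl group on the same aromatic ring, the account expects its number to lie in the neighbourhood of compound 2, with room on either side.

Compound 4 is therefore estimated at 18 nM in this assay, within a range of 6 nM to 60 nM, which means an expected step of a 1.2-fold lower number from compound 2 to compound 4 (0.06 log units; within the scatter) that is not expected to exceed the usual scatter.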

Compound 4, dissociation constant: 117 nM
For compound 4 the middle estimate is 6.5-fold (0.81 log units) below the measured one; the measured number lies above the stated range.
By their numbers in this assay, from the lowest: compound 1; then compound 2; then compounds 4 and 3 (each within the scatter of the next).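

The result shows that in this assay it is not only the presence of the methyl group on this aromatic ring that counts, but also where it sits: 2-methylphenyl in place of 4-methylphenyl gives a 5.7-fold higher number from compound 2 to compound 4 (0.75 log units; beyond the scatter). Measured from the compound without any methyl group, the 2-methylphenyl group gives an 18-fold higher number from compound 1 to compound 4 (1.25 log units; beyond the scatter), a large step, whereas the 4-methylphenyl group gives only the modest 3.1-fold higher number from compound 1 to compound 2 (0.49 log units; beyond the scatter), so both placements raise the number, but to clearly different extents. Nothing available explains why the placement of this one group matters so much on this read-out.

The compounds shown leave open whether a methoxy group or a chlorine atom in place of the methyl would follow the same order between the two placements, or whether the size of the step belongs to methyl alone. On these data alone, it also remains open whether 2-methylphenyl would give a step of similar size on the chain one member longer that compound 3 carries, since that chain is paired here only with 4-methylphenyl.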